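The source may hold more compounds than are shown below. What is called first, only, known or untested is meant among the compounds shown, and "the series" means these compounds.

Compound 1, with the structure `CC1(C)C2CC[C@@H](Cc3ccccc3C(=O)O)C[C@@]2(C)CC[C@@H]1O`, has the highest number among the three compounds measured in a functional assay on SK-MEL cells (Homo sapiens) for cytotoxicity (a higher number here means a weaker inhibitor, a lower number a stronger inhibitor), where compound 1 gives 484000 nM. Compound 3, `CC1(C)C2CCC[C@H](/C=C/c3cccc(C(=O)O)c3)[C@@]2(C)CC[C@@H]1O`, gives 269000 nM, a gap that stays within the scatter, while compound 2, `CC1(C)C2CCC[C@H](/C=C/c3ccccc3C#N)[C@@]2(C)CC[C@@H]1O`, gives 155000 nM, a gap beyond the scatter. Compound 4, `COc1ccc(CO[C@H]2CC[C@]3(C)C[C@H](Cc4ccccc4C(=O)O)CCC3C2(C)C)cc1`, differs from compound 1 in one place: 4-methoxybenzyl in place of hydrogen on an oxygen on a saturated carbon. Going by the values given here, no measured pair shows this change, so its effect is not known from these data. I expect a modest step from compound 1 to compound 4 of a 2.4-fold lower number from compound 1 to compound 4 (0.38 log units; beyond the scatter), toward a somewhat lower number, and this is only an expectation. For compound 4 the estimate is 200000 nM, within the range 50000 nM to 600000 nM.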

Compound 4, half-maximal inhibitory concentration: 166000 nM
The estimate for compound 4 lay 1.2-fold (0.08 log units) above the measured number, within the range that was stated.
By their numbers in this assay, from the lowest: compounds 2, 4, 3 and 1 (each within the scatter of the next, the first and the last beyond it).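

Going by these compounds alone, putting 4-methoxybenzyl in place of the hydrogen on this oxygen gives a 2.9-fold lower number from compound 1 to compound 4 (0.46 log units; beyond the scatter) in this assay, the first measured step at this position. The free hydroxy group is therefore not needed to keep this cytotoxicity, and a group of this size on the oxygen is tolerated with a modest gain. Nothing available explains the step. As far as these compounds go, whether a methyl or an unsubstituted benzyl on the same oxygen would give a similar step remains open, as does whether the change would act the same way in compound 2 or compound 3.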